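The source may hold more compounds than are shown below. What is called first, only, known or untested is meant among the compounds shown, and "the series" means these compounds.

Working notes on the series. Compound 2 `Cc1cc(NC(=O)Nc2ccc(N)cc2)c2ccccc2n1` is the anchor here. In an ADME assay on HepG2 cells (Homo sapiens) for cytotoxicity, with a stated time of 72 h (on this read-out lower numbers stand for an effect already at smaller amounts and higher numbers for an effect only at larger amounts of compound), compound 2 gives only a limit, > 25000 nM. Compound 1 `COc1ccc(NC(=O)Nc2cc(C)nc3ccccc23)cc1F` in this assay also gives only a limit, > 25000 nM. Compound 3 `Cc1cc(NC(=O)Nc2ccccc2F)c2ccccc2n1` likewise gives only a limit, > 25000 nM. Among the measured compounds shown here, the single step between measured compounds, a step that the two limits leave unreadable from compound 2 to compound 3, cannot therefore be sized, given (the limit of > 25000 nM in this assay, at which 3 of the 3 values shown sit). Compound 4 `COC(=O)c1ccc(NC(=O)Nc2cc(C)nc3ccccc23)cc1` differs from compound 2 by methoxycarbonyl in place of amino on an aromatic carbon. For the measured compounds named here, no measured step bears directly on this change, and the one step in the set is unreadable, so the expectation is that compound 4 again returns only a limit, with no step beyond the scatter expected as a step that the limit leaves unreadable from compound 2 to compound 4. Compound 4 is estimated at 40000 nM, with a range from 25000 nM to 100000 nM.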

Compound 4, half-maximal effective concentration: 20000 nM
Beside the measured number, compound 4's estimate is 2.0-fold (0.30 log units) above it; the measured number lies below the stated range.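

In this assay, compound 4 alone among the compounds shown gives a number rather than a limit, and the others stay at the ceiling: the limit of > 25000 nM in this assay, at which 3 of the 4 values shown sit.

Methoxycarbonyl in place of amino on this aromatic carbon, para to a large group, gives an at least 1.2-fold lower number from compound 2 to compound 4 (0.09 log units; that floor lies within the scatter). A real change at this position is therefore not established, though a measurable read-out is now within reach for the series.

On these data alone, the true size of the step stays open, with compound 2 known only as a limit. Also open, as far as these compounds go, is whether a carboxylic acid or a primary amide at this place would give a number.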